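The compounds below may be only part of what the source reports. "The series", "measured", "known", "first", "only" and "open" are said of these compounds alone.

In an assay on cells for inhibition of Rho-associated protein kinase 2 (Homo sapiens), read by radiometric assay and 33P incorporation, in the presence of a further agent that is not named here (a lower number here means a stronger inhibitor, a higher number a weaker inhibitor), compound 2 `CCCCOC(=O)c1cccc(NC(=O)c2cccc(-c3cc(C(=O)Nc4ccncc4F)ccc3CN)c2)c1` gives 27 nM. Compound 1 `CCCOC(=O)c1cccc(C(=O)Nc2cccc(-c3cc(C(=O)Nc4ccncc4F)ccc3CN)c2)c1` gives 1.8 nM, so compound 2 holds the higher of the two numbers, and the gap between them lies beyond the usual scatter of repeated measurements. For compound 3 `COCCOC(=O)c1ccc(F)c(C(=O)Nc2cccc(-c3cc(C(=O)Nc4ccncc4F)ccc3CN)c2)c1` the result of < 1 nM is a limit of the assay and not a number, (the limit of < 1 nM in this assay, at which 1 of the 3 values shown sits). Compound 4 `NCc1ccc(C(=O)Nc2ccncc2F)cc1-c1cccc(C(=O)Nc2cccc(CC(=O)O)c2)c1` differs from compound 2 in one place: carboxymethyl in place of butoxycarbonyl on an aromatic carbon. Going by the values given here, no pair of measured compounds shows this change, so no measured step sets its size. A step of about a 1.4-fold lower number from compound 2 to compound 4 (0.13 log units; within the scatter) is expected, which stays within the scatter. Compound 4 is therefore expected to give 20 nM, with a likely range from 5 nM to 80 nM.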

Compound 4, half-maximal inhibitory concentration: 1.5 nM
For compound 4 the middle estimate is 13-fold (1.12 log units) above the measured one; the measured number lies below the stated range.
By their numbers in this assay, from the lowest: compounds 4 and 1 (each within the scatter of the next); then compound 2. At a limit, below all of these: compound 3.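

Swapping butoxycarbonyl for carboxymethyl gives an 18-fold lower number from compound 2 to compound 4 (1.26 log units; beyond the scatter) in this assay, so the number depends strongly on the group at this aromatic carbon, and an ester there is not needed for a low number. Carboxymethyl has fewer heavy atoms and adds a hydrogen-bond donor, and this single swap changes both at once. No measurement shown accounts for the size of this step. From the compounds shown here alone, it remains open whether the shorter chain or the donor matters more. An amine or a methyl ester on the same short chain, placed on this carbon, could help separate the two.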